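The compounds below may be only part of what the source reports. "The series", "measured", "known", "first", "only" and "open" are said of these compounds alone.

In a functional assay on the whole organism (Tail, strain ICR) with Mus musculus as the target, in the tail flick test, with a stated time of 150 min, at a dose of 25 umol/kg by the oral route (a lower number here means a weaker effect, a higher number a stronger effect of the compound at the dose given), the measured compounds are these:

Compound 1 `CC[C@H](C)[C@H](NC(=O)CN(c1nc(Cl)nc2[nH]cnc12)C1CC1)C(=O)OCc1ccccc1` gives 6.9%.
Compound 2 `NC(=O)CC[C@H](NC(=O)CN(c1ncnc2c1ncn2C1CCCCO1)C1CC1)C(=O)OCc1ccccc1` gives 10.7%.
Compound 3 `O=C(CN(c1ncnc2c1ncn2C1CCCCO1)C1CC1)NCC(=O)OCc1ccccc1` gives 7.26%.

Compound 1 has the lowest of the three numbers, but its gap to compound 3 and its gap to compound 2 both lie within the scatter, so the three cannot be ranked. Compound 4 `C[C@H](NC(=O)CN(c1nc(Cl)nc2[nH]cnc12)C1CC1)C(=O)OCc1ccccc1` differs from compound 1 by methyl in place of sec-butyl on a saturated chain carbon bound to an amide-type nitrogen and a carbonyl carbon. Going by the values given here, one measured step touches the same place: a number 3.4 percentage points lower from compound 2 to compound 3 (within the scatter), which also trimmed the side chain on that carbon and produced no change beyond the scatter. Compound 4 is therefore expected to stay near compound 1, with a step of a number 0.6 percentage points higher from compound 1 to compound 4 (within the scatter) in this assay. The estimate for compound 4 is 7.5%, within 1% to 16%.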

Compound 4, a percentage reported as activity, at one dose (the size of the read-out at that dose, not a potency): 23%
Compound 4: the middle estimate sits 15.5 percentage points below what was measured; measured number above the stated range.
By their numbers in this assay, from the lowest: compounds 1, 3 and 2 (each within the scatter of the next); then compound 4.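

In this assay, the group on the saturated chain carbon bound to an amide-type nitrogen and a carbonyl carbon turns out to matter on the core of compound 1: methyl in place of sec-butyl gives a clear gain (a number 16.1 percentage points higher from compound 1 to compound 4 (beyond the scatter)). The earlier step at this place (a number 3.4 percentage points lower from compound 2 to compound 3 (within the scatter)) had suggested no such sensitivity, though it lay on a different core and involved different groups. Nothing measured here gives a reason for the gain.

Going by these compounds alone, whether a smaller side chain helps in general remains open, since only this one pair shows it. Also open, from the compounds shown here alone, is what hydrogen, an amine or a carboxylic acid on that carbon would give on the core of compound 1.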